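Removing One Methyl from the Dimethyl Thiazole Ring

The source may hold more compounds than are shown below. What is called first, only, known or untested is meant among the compounds shown, and "the series" means these compounds.

Compound 1 `C#CCSc1nc(Sc2nncs2)c(C#N)c(-c2cc(OC)c(OC)c(OC)c2)n1` gives 7960 nM in a functional assay on PC-9 cells (Homo sapiens) for antiproliferative activity, read by MTT assay; on this read-out lower numbers stand for stronger inhibition and higher numbers for weaker inhibition.
Compound 2 `C#CCSc1nc(Sc2nc(C)c(C)s2)c(C#N)c(-c2cc(OC)c(OC)c(OC)c2)n1` gives only a limit of the assay, > 20000 nM, in this assay.

Compound 2 therefore stands at the weak end of the two results shown: its value is a limit of the assay rather than a number. Compound 3 `C#CCSc1nc(Sc2nc(C)cs2)c(C#N)c(-c2cc(OC)c(OC)c(OC)c2)n1` differs from compound 2 by hydrogen in place of methyl on an aromatic carbon. For the measured compounds named here, the single measured step, an at least 2.5-fold higher number from compound 1 to compound 2 (0.40 log units; beyond the scatter), exchanged one whole ring for another and did not touch a methyl group, so no measured step bears directly on this change; it shows only that the ring carried by compound 2 weakens the result compared with compound 1. Compound 3 is expected to remain close to compound 2, with a step of a number no higher from compound 2 to compound 3 (the limit leaves the size open) in this assay, so that a limit may again be reported. Compound 3 is estimated at 20000 nM, within a range from 8000 nM to 50000 nM.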

Compound 3, half-maximal inhibitory concentration: > 20000 nM
Compound 3 gave a limit, no number (the forecaster's own chance of this, stated with the estimate: 55%); the middle value sits exactly at the limit.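

In this assay, hydrogen in place of methyl on this aromatic carbon, next to the ring sulfur, does not bring the result back to a readable number, as compound 3 also ends at a limit of the assay. The 4-methyl-1,3-thiazol-2-yl ring still gives an at least 2.5-fold higher number from compound 1 to compound 3 (0.40 log units; beyond the scatter), so the weaker result seen against the 1,3,4-thiadiazol-2-yl ring does not need the methyl group at this position. The step between the two limits cannot be read, so any effect of this methyl group on its own stays hidden: the limit of > 20000 nM in this assay, at which 2 of the 3 values shown sit.

Going by these compounds, it remains open whether another group on this carbon, such as an amine or a carboxylic acid, would give a number rather than a limit. Also open, on these data alone, is how a thiazole ring carrying no methyl group at all would compare with compound 1.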